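The source may report more compounds than this note shows. Statements on the series, on what has been measured and on what is new or still open speak of the compounds shown alone.

Working notes on the side chain carried on sulfur, read in a functional assay on HT cells (Homo sapiens) for antiproliferative activity, read by fluorescence, with a stated time of 72 h; a lower number here means a stronger inhibitor of growth, a higher number a weaker inhibitor of growth. Compound 1 (`CC(C)c1n[nH]c2c(NCc3ccc(-c4ccccn4)cc3)nc(SCC3CNC(=O)O3)nc12`) gives 80 nM, compound 2 (`CC(C)c1n[nH]c2c(NCc3ccc(-c4ccccn4)cc3)nc(SCCCO)nc12`) gives 109 nM and compound 3 (`CC(C)c1n[nH]c2c(NCc3ccc(-c4ccccn4)cc3)nc(SC[C@H](O)CN)nc12`) gives 63 nM. Compound 3 therefore stands within the scatter of both other compounds.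

The next structure is compound 4 (`CC(=O)NCCSc1nc(NCc2ccc(-c3ccccn3)cc2)c2[nH]nc(C(C)C)c2n1`), with the change (acetamidomethyl in place of 2-amino-1-hydroxyethyl on a saturated chain carbon bound to a sulfur). In words, acetamidomethyl takes the place of 2-amino-1-hydroxyethyl on a saturated chain carbon bound to a sulfur.

The three measured replacements at this place bear on the change: a 1.4-fold higher number from compound 1 to compound 2 (0.13 log units; within the scatter), a 1.3-fold lower number from compound 1 to compound 3 (0.10 log units; within the scatter) and a 1.7-fold lower number from compound 2 to compound 3 (0.24 log units; within the scatter). All three lie within the scatter. Going by the values given here, no measured compound carries the acetamido chain, so this evidence is indirect. No step beyond the scatter is expected in this assay, and no firm direction can be assigned. The estimated step, expected to remain within the scatter, is a 1.3-fold higher number from compound 3 to compound 4 (0.13 log units; within the scatter). Compound 4 is estimated at 85 nM, with an expected range of 40 nM to 190 nM.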

Compound 4, concentration for 50% growth inhibition: 71 nM
Beside the measured number, compound 4's estimate is 1.2-fold (0.08 log units) above it; the measured number falls inside the stated range.
By their numbers in this assay, from the lowest: compounds 3, 4, 1 and 2 (each within the scatter of the next).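

In this assay the acetamido chain of compound 4 reads level with the three other side chains on sulfur (a 1.1-fold higher number from compound 3 to compound 4 (0.05 log units; within the scatter); a 1.5-fold lower number from compound 2 to compound 4 (0.19 log units; within the scatter); a 1.1-fold lower number from compound 1 to compound 4 (0.05 log units; within the scatter)). Going from 3-amino-2-hydroxypropyl to 2-acetamidoethyl removes the defined stereocentre and takes the group from 2 hydrogen-bond donors to 1, yet the step stays within the scatter, so neither feature separates these four compounds at this position. Nothing available accounts for why these chains read alike.

On these data alone, whether this flat reading extends to a carboxylic acid, a tertiary amine, a plain alkyl chain or a longer chain on sulfur remains open. Also open, as far as these compounds go, is whether a side chain exists at this place that moves the number beyond the scatter in this assay.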